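Trifluoromethoxy to ethoxy: from compound 2 to compound 3

A few compounds are considered here, and "the series" means these few. Any claim that something is new, unique, unknown or untested is made for them only; others in the source may bear on it.

Measured in a functional assay on A549 cells (Homo sapiens) for antiproliferative activity, read by MTT assay, with a stated time of 72 h; a higher number here means a weaker inhibitor, a lower number a stronger inhibitor:
- compound 1 `CCOc1ccc(-c2ncnn2-c2cc(OC)c(OC)c(OC)c2)cc1Cl` gives 10 nM
- compound 2 `COc1cc(-n2ncnc2-c2ccc(OC(F)(F)F)cc2)cc(OC)c1OC` gives > 10000 nM

Compound 2 gives > 10000 nM, and this is a limit of the assay, not a number. It stands at the end of the measurable range: the limit of > 10000 nM in this assay, at which 1 of the 2 values shown sits.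

Compound 3 `CCOc1ccc(-c2ncnn2-c2cc(OC)c(OC)c(OC)c2)cc1` is still unmeasured in this assay. It differs from compound 2 by ethyl in place of trifluoromethyl on an oxygen on an aromatic ring. Going by the values given here, no step between measured compounds isolates this change, so the expectation is indirect. It rests on compound 1, which also carries ethoxy and gives 10 nM. A large gain in potency, well beyond the scatter, is expected for an at least 330-fold lower number from compound 2 to compound 3 (2.52 log units; beyond the scatter). For compound 3 the estimated value is 30 nM, with an expected range of 4 nM to 300 nM.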

Compound 3, half-maximal inhibitory concentration: 100 nM
Estimate against measurement, compound 3: 3.3-fold (0.52 log units) below, and the stated range covers the measured number.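

In this assay, the group on this oxygen proves decisive for the shared core, with ethyl in place of trifluoromethyl giving an at least 100-fold lower number from compound 2 to compound 3 (2.00 log units; beyond the scatter). From the compounds shown here alone, the true size of this step remains unknown, since the value of compound 2 is a limit of the assay and not a number: the limit of > 10000 nM in this assay, at which 1 of the 3 values shown sits. Ethoxy alone does not set the potency, as hydrogen in place of chloro on the aromatic carbon gives a 10-fold higher number from compound 1 to compound 3 (1.00 log units; beyond the scatter), a further step beyond the scatter.

The compounds shown leave open whether the step follows from the ethyl group itself or from the loss of trifluoromethyl, and a methyl group or a longer chain such as propyl on this oxygen would separate the two. Also open, going by these compounds, is whether chloro would bring any measurable potency to the trifluoromethoxy compound.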